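Carbonate and ester prodrugs of the shared core: cytotoxicity notes

The source may hold more compounds than are shown below. What is called first, only, known or untested is meant among the compounds shown, and "the series" means these compounds.

Compound 1 `Cc1cn(C2CC(N=[N+]=[N-])C(COC(=O)OCCCCCCCCO)O2)c(=O)[nH]c1=O` and compound 2 `Cc1cn(C2CC(N=[N+]=[N-])C(COC(=O)OCCCN)O2)c(=O)[nH]c1=O` share one core and differ only in the side chain. In a functional assay on MT4 cells (Homo sapiens) for cytotoxicity (on this read-out lower numbers stand for higher toxicity in this test and higher numbers for lower toxicity in this test), compound 1 reaches only the limit > 50000 nM. In this assay compound 2 likewise reaches only the limit > 50000 nM. The step that the two limits leave unreadable from compound 1 to compound 2 is thus not readable. Compound 3 `Cc1cn(C2CC(N=[N+]=[N-])C(COC(=O)CCCC(=O)OC(C)(C)C)O2)c(=O)[nH]c1=O` differs from compound 2 by 3-(tert-butoxycarbonyl)propyl in place of 3-aminopropoxy on a carbonyl carbon. Among the measured compounds shown here, no measured step bears on this change; the only evidence is the limit of > 50000 nM in this assay, at which 2 of the 2 values shown sit. No shift beyond the scatter is expected, and the estimate for compound 3 is 70000 nM, range 30000 nM to 200000 nM, an expected step that the limit leaves unreadable from compound 2 to compound 3.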

Compound 3, half-maximal cytotoxic concentration: > 50000 nM
Compound 3: no number, only a limit; the forecaster's own chance of this, stated with the estimate: 80%; the middle value lies beyond the limit too.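

No step among compound 1, compound 2 and compound 3 can be read in this assay, since each gives a limit and not a number: the limit of > 50000 nM in this assay, at which 3 of the 3 values shown sit.

The compounds shown leave open how far the true half-maximal cytotoxic concentrations lie past that limit, and whether these side chains differ at all.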